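Swapping an Ester for an Acetamido Group on Coumarin Migration Inhibitors

A few compounds are considered here, and "the series" means these few. Any claim that something is new, unique, unknown or untested is made for them only; others in the source may bear on it.

Compound 1 `CC(C)C(=O)OCc1ccc2oc(=O)c(C(=O)Oc3cccc(Br)c3)cc2c1` was tested in a functional assay on HT-1080 cells (Homo sapiens), read by transwell migration, with a stated time of 24 h, tested at 1 uM (on this read-out higher numbers stand for a weaker effect at the one concentration tested and lower numbers for a stronger effect), and gave 37.8%. Among the measured compounds shown here, of the two numbers measured so far, that of compound 1 is the lowest, meaning the stronger effect on cell movement. For the measured compounds named here, its only neighbour is compound 2 `O=C(Oc1cccc(Cl)c1)c1cc2cc(CCl)ccc2oc1=O`, which in this assay gave 79.8%, a gap that lies beyond the scatter; since compound 2 differs from compound 1 in more than one place, no single structural cause can be read from that pair.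

Compound 3 `CC(=O)NCc1ccc2oc(=O)c(C(=O)Oc3cccc(Br)c3)cc2c1` is the next compound, not yet measured. Compared with compound 1, the change is acetamido in place of (isopropylcarbonyl)oxy on a saturated chain carbon bound to an aromatic carbon. Going by the values given here, the data hold no measured step that isolates this kind of exchange. The expected size therefore rests on a guess. A modest shift toward a weaker effect seems most likely, so the step of a number 14.2 percentage points higher from compound 1 to compound 3 (beyond the scatter) is expected in this assay. Compound 3 is therefore estimated to give 52% in this assay, within the range 30% to 75%.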

Compound 3, a percentage reported as activity, at one concentration (the size of the read-out at that concentration, not a potency): 36.9%
Beside the measured number, compound 3's estimate is 15.1 percentage points above it; the range from low to high includes it.
By their numbers in this assay, from the lowest: compounds 3 and 1 (each within the scatter of the next); then compound 2.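

In this assay, putting acetamido in place of (isopropylcarbonyl)oxy on a saturated chain carbon bound to an aromatic carbon gives a number 0.9 percentage points lower from compound 1 to compound 3 (within the scatter), so the two compounds cannot be told apart. Among the compounds shown here, this is the first single-place comparison, and it shows that the ester linkage of compound 1 is not required at this position for the effect seen at the one concentration tested: a group of 4 heavy atoms with a hydrogen-bond donor serves as well as one of 6 heavy atoms without a donor. No measurement at hand explains this match. As far as these compounds go, whether an amine, a carboxylic acid or a longer chain on the same carbon would keep the effect remains open. So does whether a different group here could give a stronger effect than compound 1 and compound 3.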